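Aryl carbonyl moved onto the oxygen of compound 2

The source may hold more compounds than are shown below. What is called first, only, known or untested is meant among the compounds shown, and "the series" means these compounds.

Compound 2 `CCCCCCCCOC1CC(=O)Nc2c1c(C)nn2-c1ncnc2nc[nH]c12` gives 8 nM in a functional assay on HEK293 cells for agonist activity at G-protein coupled receptor 39 (Homo sapiens), read by scintillation proximity assay and inositol phosphate accumulation, with a stated time of 75 min, in the presence of a further agent that is not named here; a lower number here means that less compound is needed, a higher number that more compound is needed for the effect. Of the three measured compounds it holds the second highest number: compound 3 `Cc1nn(-c2ncnc3nc[nH]c23)c2c1C(OCCn1nccc1C)CC(=O)N2` gives 10 nM and lies within the scatter of compound 2, whereas compound 1 `Cc1nn(-c2ncnc3nc[nH]c23)c2c1C(OCC(=O)c1ccc(F)cc1)CC(=O)N2` gives 3 nM, the lowest of the set. Compound 4 `Cc1nn(-c2ncnc3nc[nH]c23)c2c1C(OC(=O)c1ccc(F)cc1)CC(=O)N2` differs from compound 2 by (4-fluorophenyl)carbonyl in place of octyl on an oxygen on a saturated carbon. The step that bears on this change is a 2.7-fold higher number from compound 1 to compound 2 (0.43 log units; beyond the scatter), where the same (4-fluorophenyl)carbonyl group, held on a saturated chain carbon bound to an oxygen on a saturated carbon, was exchanged for heptyl. Undoing that exchange, with the group now placed on the oxygen itself, a modest downward step is expected, a 2.0-fold lower number from compound 2 to compound 4 (0.30 log units; within the scatter). Compound 4 is therefore estimated at 4 nM, within 1.5 nM to 12 nM.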

Compound 4, half-maximal effective concentration: 4 nM
For compound 4 middle estimate and measured number coincide at the digits printed; the measured number falls inside the stated range.
By their numbers in this assay, from the lowest: compounds 1, 4, 2 and 3 (each within the scatter of the next, the first and the last beyond it).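

On an oxygen on a saturated carbon, (4-fluorophenyl)carbonyl in this assay cannot be told apart from octyl (a 2.0-fold lower number from compound 2 to compound 4 (0.30 log units; within the scatter)) or from ((4-fluorophenyl)carbonyl)methyl (a 1.3-fold higher number from compound 1 to compound 4 (0.12 log units; within the scatter)). It separates only from the group carried by compound 3 (a 2.5-fold lower number from compound 3 to compound 4 (0.40 log units; beyond the scatter)), so this position accepts the aryl carbonyl held directly on the oxygen as well as one carbon further out. Nothing here gives a reason for this. Open remains how an amine, a carboxylic acid or a chain longer than octyl would fare on this oxygen, and whether the fluorine of the phenyl ring contributes at all.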